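The source may hold more compounds than are shown below. What is called first, only, known or untested is meant among the compounds shown, and "the series" means these compounds.

Within the data shown here, in an ADME assay on microsomes from liver (Homo sapiens) for metabolic stability, read by LC-MS, with a stated time of 30 min, tested at 0.5 uM (on this read-out higher numbers stand for a more stable compound and lower numbers for a less stable compound), compound 1 (`c1ccc(-n2ccc(-c3csc(N=C4NCCCN4)n3)n2)cc1`) gives 38% while compound 2 (`Oc1ccc(-c2nc(-c3csc(N=C4NCCCN4)n3)cs2)cc1`) gives 86% as the only other number so far. Compound 2 thus holds the higher of the two numbers, and its gap to compound 1 lies beyond the usual scatter of such measurements. The next structure is compound 3 (`c1cc(-c2nc(-c3csc(N=C4NCCCN4)n3)cs2)ccn1`), which is compound 2 with a single change: pyridin-4-yl in place of 4-hydroxyphenyl on an aromatic carbon of a five-membered aromatic ring with 1 nitrogen and 1 sulfur (pyridin-4-yl in place of 4-hydroxyphenyl on an aromatic carbon). Among the measured compounds shown here, no measured pair of compounds shows what this swap does, so any forecast here is rough. Compound 2 at 86% has far more room to fall than to rise on this scale, and compound 1 at 38% shows that a much lower number is possible in this small set. The estimated step of a number 14 percentage points lower from compound 2 to compound 3 (beyond the scatter) is a moderate fall, expected to lie a little beyond the scatter. For compound 3 the estimated value is 72% and the expected range runs from 50% to 92% on this scale.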

Compound 3, percent of the compound remaining: 58%
For compound 3 the middle estimate is 14 percentage points above the measured one; the range from low to high includes it.
By their numbers in this assay, from the lowest: compound 1; then compound 3; then compound 2.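

Swapping 4-hydroxyphenyl for pyridin-4-yl on this aromatic carbon gives, in this assay, a number 28 percentage points lower from compound 2 to compound 3 (beyond the scatter) as the first reading of a single change in this set. With the rest of the molecule unchanged, the group on this five-membered aromatic ring with 1 nitrogen and 1 sulfur clearly affects the percent remaining, and the choice between these two six-membered aromatic rings matters. The swap alters more than one feature at once, since the leaving group has a hydrogen-bond donor and the entering group has none, while a ring nitrogen also appears, and no supporting measurement shows which feature accounts for the fall.

From the compounds shown here alone, a plain phenyl group on this same carbon would help separate the loss of the hydroxyl from the arrival of the ring nitrogen, and its result remains open here. Also open, going by these compounds, is how an amine or a carboxylic acid on the six-membered ring would read in this assay, and whether the same swap would give a similar step on a different core.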